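This account rests on a few compounds, and the source may have more. Where it says the series, first, only, none or still open, it means among the compounds named here.

Measured so far in an ADME assay on MCF-10A cells (Homo sapiens) for inhibition, with a stated time of 48 h (a higher number here means a weaker inhibitor, a lower number a stronger inhibitor), both entries being limits of the assay:
Compound 1 `Cc1ccccc1-c1noc([C@@H]2CCCN2C(=O)Nc2ccc(Cl)cc2)n1`: > 50000 nM
Compound 2 `O=C(Nc1ccc(Cl)cc1)N1CCC[C@H]1c1nc(-c2ccccc2Cl)no1`: > 50000 nM

Compound 2 has no numerical value in this assay. Its reading of > 50000 nM is a limit. The same holds across the measured set, which shows (the limit of > 50000 nM in this assay, at which 2 of the 2 values shown sit).

Compound 3 `Cc1cccc(-c2noc([C@@H]3CCCN3C(=O)Nc3ccc(Cl)cc3)n2)c1` carries 3-methylphenyl in place of 2-chlorophenyl on an aromatic carbon. This carbon lies on a five-membered aromatic ring with 2 nitrogen and 1 oxygen, between two ring nitrogen atoms.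

Going by the values given here, only one measured step bears on this change: a step that the two limits leave unreadable from compound 1 to compound 2. It is chloro in place of methyl on an aromatic carbon, and it gives no size to carry forward. No step beyond the scatter is therefore expected in this assay, and no direction can be assigned. Compound 3 is expected to read most likely as a limit again, although a number close to that limit remains possible.

The estimated step is a number no higher from compound 2 to compound 3 (the limit leaves the size open).

For compound 3 the expected value is 50000 nM, with an estimated range of 20000 nM to 100000 nM.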

Compound 3, half-maximal inhibitory concentration: > 50000 nM
Compound 3 ended at the assay's limit (the forecaster's own chance of this, stated with the estimate: 85%); the middle value lies on the limit itself.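

In this assay compound 3 gives > 50000 nM, which is a limit, so no step among compound 1, compound 2 and compound 3 can be read: the limit of > 50000 nM in this assay, at which 3 of the 3 values shown sit.

The compounds shown leave open whether 2-methylphenyl, 2-chlorophenyl and 3-methylphenyl differ at all in this assay, and what numerical value any of them would give.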